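The compounds below may be only part of what the source reports. "The series", "measured", "known", "first", "only" and "open" are said of these compounds alone.

Working notes on the series. The common core is seen in compound 1 `COc1ccc(-n2c(SC)nnc2-c2cc(OC)c(OC)c(OC)c2)cc1`, and the three measured compounds differ only in what sits on the saturated chain carbon bound to a sulfur. In a functional assay on HepG2 cells (Homo sapiens) for inhibition, read by MTT assay, with a stated time of 48 h (on this read-out lower numbers stand for stronger inhibition and higher numbers for weaker inhibition), compound 1 reaches only a limit of the assay, > 60000 nM. Compound 2 `COc1ccc(CSc2nnc(-c3cc(OC)c(OC)c(OC)c3)n2-c2ccc(OC)cc2)cc1` gives 41100 nM in this assay, and compound 3 `COc1ccc(C(=O)CSc2nnc(-c3cc(OC)c(OC)c(OC)c3)n2-c2ccc(OC)cc2)cc1` gives 18100 nM. The step of an at least 1.4-fold lower number from compound 1 to compound 2 (0.16 log units; that floor lies within the scatter) rests on the limit of > 60000 nM in this assay, at which 1 of the 3 values shown sits, and at its floor stays within the scatter, whereas an at least 3.3-fold lower number from compound 1 to compound 3 (0.52 log units; beyond the scatter) is beyond it, and a 2.3-fold lower number from compound 2 to compound 3 (0.36 log units; beyond the scatter) separates the carbonyl-bearing substituent from the plain 4-methoxyphenyl one.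

Compound 4 `COc1ccc(-n2c(SCC(=O)c3ccc4ccccc4c3)nnc2-c2cc(OC)c(OC)c(OC)c2)cc1` differs from compound 1 by (naphthalen-2-yl)carbonyl in place of hydrogen on a saturated chain carbon bound to a sulfur. Going by the values given here, the measured step that bears most directly on it is the one from compound 1 to compound 3, where an aryl carbonyl enters at the same place; compound 4 carries the (naphthalen-2-yl)carbonyl instead of the (4-methoxyphenyl)carbonyl of compound 3, and no measured pair tells how that exchange plays out. For compound 4 the expected step in this assay is an at least 3.5-fold lower number from compound 1 to compound 4 (0.54 log units; beyond the scatter), a lowering of the number of about the size seen with compound 3. Compound 4 is accordingly estimated at 17000 nM, with a range from 5500 nM to 50000 nM.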

Compound 4, half-maximal inhibitory concentration: > 60000 nM
Compound 4 gave a limit, no number; the forecaster's own chance of this, stated with the estimate: 12%; at least 3.5-fold (0.54 log units) between middle value and limit.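

At this position the group on the carbonyl carbon matters in this assay: naphthalen-2-yl in place of 4-methoxyphenyl gives a clear loss (an at least 3.3-fold higher number from compound 3 to compound 4 (0.52 log units; beyond the scatter)). Going by these compounds alone, an aryl carbonyl on the saturated chain carbon bound to a sulfur therefore does not carry the lowering on its own, and the earlier compounds, which held only one such group, could not show this. Set against the plain 4-methoxyphenyl substituent, the (naphthalen-2-yl)carbonyl gives a step whose floor stays within the scatter (an at least 1.4-fold higher number from compound 2 to compound 4 (0.16 log units; that floor lies within the scatter)), so no order can be stated for that pair, and the step from compound 1 to compound 4 cannot be read because both compounds stand at a limit and give no number: the limit of > 60000 nM in this assay, at which 2 of the 4 values shown sit.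

Open, from the compounds shown here alone, is whether the lowering depends on the methoxy group itself or on the ring that bears it, which a plain phenyl or a 4-chlorophenyl on the carbonyl carbon would separate. Also open, going by these compounds, is whether an amine or a carboxylic acid at the end of a longer chain on the same saturated carbon would move the number in this assay at all.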